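The source may hold more compounds than are shown below. What is called first, only, known or untested is meant among the compounds shown, and "the series" means these compounds.

In a functional assay on DU-145 cells (Homo sapiens) for inhibition, read by sulforhodamine B assay, with a stated time of 48 h (on this read-out higher numbers stand for weaker inhibition of growth and lower numbers for stronger inhibition of growth), compound 1 (`Cc1ccc(NC(=O)/C=C/c2ccccc2)c(C(N)=O)c1`) gives 3660 nM and compound 2 (`NC(=O)c1cc(Br)ccc1NC(=O)/C=C/c1ccccc1`) gives 935 nM, the lower of the two numbers. Compound 3 (`NC(=O)c1cc(I)ccc1NC(=O)/C=C/c1ccccc1`) has iodo in place of bromo on an aromatic carbon. For the measured compounds named here, the only measured step that bears on this change, a 3.9-fold lower number from compound 1 to compound 2 (0.59 log units; beyond the scatter), was modest and replaced methyl rather than bromo, so only a slight fall, not clearly beyond the scatter, is expected in this assay. The expected step is a 1.2-fold lower number from compound 2 to compound 3 (0.10 log units; within the scatter). For compound 3 the estimated value is 750 nM, with an expected range of 320 nM to 1700 nM.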

Compound 3, concentration for 50% growth inhibition: 477 nM
The estimate for compound 3 lay 1.6-fold (0.20 log units) above the measured number; measured number inside the range.
By their numbers in this assay, from the lowest: compounds 3 and 2 (each within the scatter of the next); then compound 1.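

In this assay, iodo in place of bromo on this aromatic carbon gives a 2.0-fold lower number from compound 2 to compound 3 (0.29 log units; within the scatter), so the two halogens cannot be told apart at this position. Iodo in place of methyl gives a 7.7-fold lower number from compound 1 to compound 3 (0.88 log units; beyond the scatter), which shows that a second halogen, and not bromo alone, stands beyond the scatter from methyl here. Nothing measured here accounts for this result. The compounds shown leave open how a smaller halogen such as fluoro or chloro would read at this position, and how an amine or a carboxylic acid would read there.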